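A few compounds are considered here, and "the series" means these few. Any claim that something is new, unique, unknown or untested is made for them only; others in the source may bear on it.

Measured so far in a functional assay on MDA-MB-231 cells (Homo sapiens) for antiproliferative activity, read by MTT assay, with a stated time of 24 h; a lower number here means a stronger inhibitor, a higher number a weaker inhibitor

compound 1 `COc1ccccc1C(=O)NC(CC(=O)O)c1ccccc1` | > 100000 nM (a limit)
compound 2 `O=C(O)CC(NC(=O)c1c(Cl)cccc1Cl)c1ccccc1` | > 100000 nM (a limit)
compound 3 `CC(C)(C)c1ccc(S(=O)(=O)NC(CC(=O)O)c2ccccc2)cc1` | > 100000 nM (a limit)

Compound 3 gives > 100000 nM and this is a limit, not a number. Within the data shown here, it shares its place with the other two compounds, as the record shows the limit of > 100000 nM in this assay, at which 3 of the 3 values shown sit, and no measured step exists among them. Compound 4 `O=C(O)CC(NS(=O)(=O)c1ccc(OC(F)(F)F)cc1)c1ccccc1` has trifluoromethoxy in place of tert-butyl on an aromatic carbon, para to a large group (trifluoromethoxy in place of tert-butyl on an aromatic carbon). With compound 3 standing at that limit, no change beyond the scatter is expected in this assay and no direction can be foreseen. The expected step of a number no higher from compound 3 to compound 4 (the limit leaves the size open) is an estimate only. Compound 4 is expected at 100000 nM within an estimated range from 30000 nM to 300000 nM in this account.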

Compound 4, half-maximal inhibitory concentration: > 100000 nM
Compound 4 ended at the assay's limit; the forecaster's own chance of this, stated with the estimate: 75%; the middle value sits exactly at the limit.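

No step can be read from compound 3 to compound 4, as both stand at a limit and not at a number: the limit of > 100000 nM in this assay, at which 4 of the 4 values shown sit. The compounds shown leave open whether trifluoromethoxy in place of tert-butyl changes anything in this assay, and how any of these compounds ranks against the others.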